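A few compounds are considered here, and "the series" means these few. Any claim that something is new, unique, unknown or untested is made for them only; others in the source may bear on it.

Two sulfones share one core: compound 1 `CC1CCN(c2c(S(=O)(=O)c3cccc(Cl)c3)cnc3ccc(F)cc23)CC1` carries 3-chlorophenyl and compound 2 `CC1CCN(c2c(S(=O)(=O)c3ccc(C#N)cc3)cnc3ccc(F)cc23)CC1` carries 4-cyanophenyl on the sulfonyl sulfur. In an assay on isolated protein for displacement of a labelled ligand from metabotropic glutamate receptor 5 (Homo sapiens), with a stated time of 60 min, tested at 1 uM (on this read-out higher numbers stand for more inhibition at the one concentration tested (going by the name of the read-out) and lower numbers for less inhibition), compound 1 gives 92% and compound 2 gives 75%; the step of a number 17 percentage points lower from compound 1 to compound 2 (beyond the scatter) leaves compound 2 as the lower of the two numbers. Compound 3 `CC1CCN(c2c(S(=O)(=O)c3ccccc3)cnc3ccc(F)cc23)CC1` differs from compound 2 by hydrogen in place of cyano on an aromatic carbon. Going by the values given here, only the step from compound 1 to compound 2 touches this aromatic ring, and it changed group and position together, so it bears only loosely on the loss of cyano alone. A rise back toward compound 1 is expected, a number 8 percentage points higher from compound 2 to compound 3 (within the scatter). Compound 3 is estimated at 83%, between 66% and 96%.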

Compound 3, a percentage reported as inhibition, at one concentration (the size of the read-out at that concentration, not a potency): 40%
Estimate against measurement, compound 3: 43 percentage points above, outside the stated range (below it).
By their numbers in this assay, from the lowest: compound 3; then compound 2; then compound 1.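

In this assay the bare phenyl sulfone marks a low point: hydrogen in place of cyano gives a number 35 percentage points lower from compound 2 to compound 3 (beyond the scatter) and hydrogen in place of chloro gives a number 52 percentage points lower from compound 1 to compound 3 (beyond the scatter). On these three compounds, either substituent on this ring goes with more inhibition than hydrogen, a gain that the comparison of the two substituted sulfones could not reveal. Nothing available explains this gain. As far as these compounds go, whether an amine or a carboxylic acid on this ring would also hold inhibition stays open, as does how chloro and cyano would compare at one shared ring position.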